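Adding a Neopentyl Amide to a Nitrile Sulfonamide

This account rests on a few compounds, and the source may have more. Where it says the series, first, only, none or still open, it means among the compounds named here.

Compound 1 `CNC(=O)CCS(=O)(=O)N1CCN(c2ccc3nncn3n2)CC1`: 700 nM
Compound 2 `N#CC1(NC(=O)CCS(=O)(=O)N2CCN(c3ccccn3)CC2)CC1`: 800 nM

Both compounds were tested in an assay on cells for inhibition of cathepsin S (Homo sapiens), read by fluorescence, with stated times of 15 min and 10 min; a lower number here means a stronger inhibitor, a higher number a weaker inhibitor. In this assay compound 2 gives 800 nM, and compound 1 gives 700 nM. Compound 2 thus has the higher of the two numbers, but its gap to compound 1 lies within the usual scatter of repeated measurements, so the two cannot be told apart on these data. Compound 3 `CC(C)(C)CC(=O)N[C@@H](CS(=O)(=O)N1CCN(c2ccccn2)CC1)C(=O)NC1(C#N)CC1` has not yet been measured. It differs from compound 2 by (neopentylcarbonyl)amino in place of hydrogen on a saturated chain carbon bound to a carbonyl carbon and a saturated chain carbon. Within the data shown here, no step between measured compounds is available here, so the effect of this change has to be judged from the group that enters alone, against the number given by compound 2 at 800 nM. The expected step in this assay is a 5.3-fold lower number from compound 2 to compound 3 (0.73 log units; beyond the scatter), toward a lower number, and it is expected to exceed the scatter. For compound 3 the estimate is 150 nM, within a range from 30 nM to 800 nM.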

Compound 3, inhibition constant: 0.09 nM
Estimate against measurement, compound 3: 1700-fold (3.22 log units) above; measured number below the stated range.
By their numbers in this assay, from the lowest: compound 3; then compounds 1 and 2 (each within the scatter of the next).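

This saturated chain carbon carries only hydrogen in compound 2, and none of the earlier compounds had shown what a substituent there would do. In this assay, (neopentylcarbonyl)amino at this position gives an 8900-fold lower number from compound 2 to compound 3 (3.95 log units; beyond the scatter), so a single change at this one place can move the number by a very large amount. No supporting information is available on what lies behind this step.

The compounds shown do not reveal which part of the entering group carries the gain, since it arrives as one piece. A bare amine or a small acetylamino group at this position would help separate the share of the amide from that of the neopentyl part, and a longer chain would show whether the neopentyl part can be extended.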